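This account rests on a few compounds, and the source may have more. Where it says the series, first, only, none or still open, it means among the compounds named here.

Compound 1 `Nc1scc(-c2ccccc2F)c1C(=O)c1ccc(Cl)cc1`: 70%
Compound 2 `Nc1scc(-c2cccc(F)c2)c1C(=O)c1ccc(Cl)cc1`: 76%
Compound 3 `Nc1scc(-c2ccc(F)cc2)c1C(=O)c1ccc(Cl)cc1`: 62%

Of the compounds shown here, three sharing one core have been tested in a functional assay on CHO cells for agonist activity at adenosine receptor A1 (Homo sapiens), read by fluorescence and ERK phosphorylation, with stated times of 30 min and 1.5 h, tested at 3 uM; on this read-out higher numbers stand for a stronger effect at the one concentration tested and lower numbers for a weaker effect. Compound 3 holds the lowest of the three numbers; its gap to compound 1 is within the scatter, whereas the step of a number 14 percentage points lower from compound 2 to compound 3 (beyond the scatter) lies beyond it. Compound 4 `Nc1scc(-c2cccc(Cl)c2)c1C(=O)c1ccc(Cl)cc1` is not yet measured; it differs from compound 3 by 3-chlorophenyl in place of 4-fluorophenyl on an aromatic carbon. Of the measured steps, only a number 14 percentage points lower from compound 2 to compound 3 (beyond the scatter) bears on this exchange, as it also sets a 3-fluorophenyl against a 4-fluorophenyl, and that step was a modest fall. Within the data shown here, no measured pair sets chlorine against fluorine. For compound 4 a modest upward step of a number 10 percentage points higher from compound 3 to compound 4 (within the scatter) is therefore expected. The estimate for compound 4 is 72%, between 56% and 88%.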

Compound 4, a percentage reported as activity, at one concentration (the size of the read-out at that concentration, not a potency): 58%
For compound 4 the middle estimate is 14 percentage points above the measured one; measured number inside the range.
By their numbers in this assay, from the lowest: compounds 4, 3, 1 and 2 (each within the scatter of the next, the first and the last beyond it).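

The exchange of chloro in place of fluoro, the only one of its kind among these compounds, gives a step of a number 18 percentage points lower from compound 2 to compound 4 (beyond the scatter), so at this position the identity of the halogen on the phenyl group counts as well as its placement. The 3-chlorophenyl group also gives a number 12 percentage points lower from compound 1 to compound 4 (beyond the scatter), while against the 4-fluorophenyl group it shows a number 4 percentage points lower from compound 3 to compound 4 (within the scatter). Nothing measured here accounts for these steps.

From the compounds shown here alone, whether the other chlorophenyl isomers follow the order of the fluorophenyl compounds remains open. So does the effect of a phenyl group carrying a methoxy group or an amine.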